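Bromo for Iodo on the Indole Ring of a Calpain Inhibitor

The source may hold more compounds than are shown below. What is called first, only, known or untested is meant among the compounds shown, and "the series" means these compounds.

Of the compounds shown here, two share a core and have been measured in an assay on isolated protein for inhibition of Calpain-1 catalytic subunit (Sus scrofa), read by FRET; on this read-out lower numbers stand for stronger inhibition and higher numbers for weaker inhibition. Compound 1 `O=C(O)/C(S)=C/c1c[nH]c2cc(F)ccc12` gives 10 nM in this assay. Compound 2 `O=C(O)/C(S)=C/c1c[nH]c2ccc(I)cc12` gives 100 nM in this assay, the higher of the two numbers, and its gap to compound 1 lies beyond the scatter. Within the data shown here, no step between measured compounds that differ in one place is available. Compound 3 `O=C(O)/C(S)=C/c1c[nH]c2ccc(Br)cc12` has not yet been measured in this assay. It differs from compound 2 by bromo in place of iodo on an aromatic carbon. Exchanging one halogen for another of the same kind of position, with nothing else changed, is expected to move the number little, perhaps slightly downward, and the step from compound 2 to compound 3 is estimated as a 1.4-fold lower number from compound 2 to compound 3 (0.15 log units; within the scatter). Compound 3 is therefore expected to give about 70 nM, within a range from 25 nM to 200 nM, in this assay.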

Compound 3, half-maximal inhibitory concentration: 6 nM
The estimate for compound 3 lay 12-fold (1.07 log units) above the measured number; the measured number lies below the stated range.
By their numbers in this assay, from the lowest: compounds 3 and 1 (each within the scatter of the next); then compound 2.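

In this assay, the choice of halogen on this aromatic carbon matters far more than a swap of one heavy atom might suggest: bromo in place of iodo gives a 17-fold lower number from compound 2 to compound 3 (1.22 log units; beyond the scatter) and the step lies beyond the scatter. The earlier compounds shown here differed in more than one place, so their gap could not be assigned to any single change, whereas this pair isolates one exchange at one position with the rest of the structure held constant. Nothing available here bears on why these two halogens differ so sharply.

Going by these compounds, it remains open where chloro, a methoxy group or a nitrile at this position would fall relative to bromo and iodo. Also open, on these data alone, is whether the same exchange would produce a step of similar size on another carbon of this aromatic ring.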